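The compounds below may be only part of what the source reports. "The series", "measured", "known", "first", "only" and "open" are said of these compounds alone.

Compound 1 `C1CN=C(NC(C2CC2)C2CC2)C1` has been tested in an assay (Oryctolagus cuniculus) for displacement of a labelled ligand from Monoamine oxidase (Homo sapiens); a lower number here means a stronger inhibitor, a higher number a weaker inhibitor. In this assay compound 1 gives < 10000 nM, which is a limit of the assay. Compound 2 `CC1CN=C(NC(C2CC2)C2CC2)C1` carries a methyl in place of hydrogen on a saturated ring carbon of the shared core. In this assay compound 2 gives < 10000 nM, again a limit of the assay. The step that the two limits leave unreadable from compound 1 to compound 2 cannot be read because the limit of < 10000 nM in this assay, at which 2 of the 2 values shown sit, leaves no number on either side. Compound 3 `CCC1CCC(NC(C2CC2)C2CC2)=N1` has not yet been measured; it differs from compound 1 by ethyl in place of hydrogen on a saturated ring carbon. Among the measured compounds shown here, the only measured step, from a hydrogen to a methyl on such a ring carbon, bears on this change, but its size is not readable, so no direction and no size beyond the scatter can be drawn from it. For compound 3 in this assay the expected value is 3000 nM, with an estimated range from 300 nM to 10000 nM. The step that the limit leaves unreadable from compound 1 to compound 3 is the expected step, and a reading that is again only a limit remains quite possible.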

Compound 3, inhibition constant: < 10000 nM
Compound 3 ended at the assay's limit; the forecaster's own chance of this, stated with the estimate: 50%; the middle value lies beyond the limit too.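

No step can be read from compound 1 to compound 3, because both compounds stop at a limit and not at a number: the limit of < 10000 nM in this assay, at which 3 of the 3 values shown sit. The compounds shown leave open how strong an inhibitor each of compound 1, compound 2 and compound 3 actually is, and whether a methyl or an ethyl in place of hydrogen on that ring carbon changes this at all.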